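Sulfonamide Piperidine Amides: a Ring Swap at the Amide Nitrogen

This account rests on a few compounds, and the source may have more. Where it says the series, first, only, none or still open, it means among the compounds named here.

Compound 1: `O=C([C@@H]1CCCN(S(=O)(=O)c2ccc(S(=O)(=O)N3CC[C@@H](O)C3)cc2)C1)N1CCC(F)(F)CC1`; in a functional assay on MIA PaCa-2 cells (Homo sapiens) for inhibition, read by MTT assay, with a stated time of 7 days (on this read-out lower numbers stand for stronger inhibition and higher numbers for weaker inhibition), compound 1 gives 210 nM.
Compound 2: `CCN(CC)S(=O)(=O)c1ccc(S(=O)(=O)N2CCC[C@@H](C(=O)N[C@H]3CC[C@H](OC)CC3)C2)cc1`; in this assay compound 2 gives 1350 nM.
Compound 3: `CC(C)CS(=O)(=O)c1ccc(S(=O)(=O)N2CCC[C@@H](C(=O)N3CCC(F)(F)CC3)C2)cc1`; in this assay compound 3 gives 80 nM.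

Among the three measured compounds, compound 2 gives the highest number in this assay; compound 1 gives a lower number and compound 3 the lowest, with both gaps beyond the scatter. Compound 4, `CCN(CC)S(=O)(=O)c1ccc(S(=O)(=O)N2CCC[C@@H](C(=O)NC3CCOCC3)C2)cc1`, differs from compound 2 at a single place, the amide-type nitrogen whose other neighbour is the carbonyl carbon: oxan-4-yl in place of 4-methoxycyclohexyl on an amide-type nitrogen. Within the data shown here, the only measured step in the set, a 2.6-fold lower number from compound 1 to compound 3 (0.42 log units; beyond the scatter), concerns a group on a sulfonyl sulfur, a different part of the shared core, and so it does not bear on the change from compound 2 to compound 4. Among the measured compounds shown here, no measured pair shows what the exchange of 4-methoxycyclohexyl for oxan-4-yl does on this read-out. Without such a precedent the step is expected to stay near the scatter, with no direction favoured, which is the meaning of a 1.1-fold higher number from compound 2 to compound 4 (0.05 log units; within the scatter). Compound 4 is therefore estimated at 1500 nM, with a range from 500 nM to 4500 nM.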

Compound 4, half-maximal inhibitory concentration: 3770 nM
The estimate for compound 4 lay 2.5-fold (0.40 log units) below the measured number; low and high end bracket the measured number.
By their numbers in this assay, from the lowest: compound 3; then compound 1; then compound 2; then compound 4.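

In this assay, among these compounds, the amide-type nitrogen proves to be a place where the number responds: oxan-4-yl in place of 4-methoxycyclohexyl gives a 2.8-fold higher number from compound 2 to compound 4 (0.45 log units; beyond the scatter) and, as higher numbers stand for weaker inhibition, this modest step is a loss that the one earlier step, made on a sulfonyl sulfur, could not show. The two groups have the same counts of hydrogen-bond donors and acceptors and neither carries a net charge, so these counts do not separate them; what differs is the heavy-atom count, the ring of carbon only against the ring with a hetero atom, and the defined stereocentres of the group that leaves. Nothing in the data at hand accounts for the step.

On these data alone, it remains open whether the same exchange moves the number in the same direction when the group on the sulfonyl sulfur is a different one. Also open, as far as these compounds go, is what an open chain such as 2-methoxyethyl, or a plain cyclohexyl ring with no oxygen, would give on this amide-type nitrogen.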